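Lengthening the chain from compound 2 to compound 3

The source may report more compounds than this note shows. Statements on the series, on what has been measured and on what is new or still open speak of the compounds shown alone.

Measured in a functional assay on HepG2 cells (Homo sapiens) for cytotoxicity, read by WST assay, with a stated time of 24 h; on this read-out lower numbers stand for higher toxicity in this test and higher numbers for lower toxicity in this test:
- compound 1 `Cc1cc(-c2ccc3cc(CO)ccc3c2)ccc1O`: > 32 ug/mL (a limit)
- compound 2 `CCCCCc1cc(-c2ccc3cc(CO)ccc3c2)ccc1O`: 3.27 ug/mL

Within the data shown here, compound 2 holds the only actual number in this assay, as the other result is a limit. Compound 3 `CCCCCCCCCc1cc(-c2ccc3cc(CO)ccc3c2)ccc1O` extends its chain: butyl in place of hydrogen on a saturated chain carbon, five bonds along the chain from an aromatic carbon, five bonds along the chain from an aromatic carbon. Among the measured compounds shown here, one measured step bears on this, the same butyl-for-hydrogen exchange on a saturated chain carbon bound to an aromatic carbon: an at least 9.7-fold lower number from compound 1 to compound 2 (0.99 log units; beyond the scatter), beyond the scatter. On that single step, a further but smaller fall in the number is expected, at a different place on the chain. The estimated change is a 2.2-fold lower number from compound 2 to compound 3 (0.34 log units; beyond the scatter). For compound 3 the estimate is 1.5 ug/mL, with an expected range of 0.4 ug/mL to 6 ug/mL.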

Compound 3, concentration lethal to 50% of the cells: 7.25 ug/mL
Beside the measured number, compound 3's estimate is 4.8-fold (0.68 log units) below it, and the stated range ends below it.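

In this assay, the response to chain length is not one-way: butyl on a saturated chain carbon, five bonds along the chain from an aromatic carbon, gives a 2.2-fold higher number from compound 2 to compound 3 (0.35 log units; beyond the scatter), the opposite direction to the earlier butyl exchange. The full chain extension still gives an at least 4.4-fold lower number from compound 1 to compound 3 (0.64 log units; beyond the scatter). That step is only a bound, because compound 1 carries a limit: the limit of > 32 ug/mL in this assay, at which 1 of the 3 values shown sits.

As far as these compounds go, whether a longer chain raises the number further, and where hexyl or heptyl would fall, stays open. So does the outcome with an amine or a carboxylic acid at the chain end.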